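The source may report more compounds than this note shows. Statements on the series, on what has been measured and on what is new or still open speak of the compounds shown alone.

Measured in a functional assay on MCF7 cells (Homo sapiens) for antiproliferative activity, read by MTT assay, with a stated time of 72 h; on this read-out lower numbers stand for stronger inhibition and higher numbers for weaker inhibition:
- compound 1 `CC1=CC[C@H]2[C@H](CC[C@]2(C)O)C(C)(C)[C@@H]1CC[C@H]1[C@]2(C)CC[C@H](OC(=O)c3ccc(C)cc3)C(C)(C)O[C@H]2CC[C@@]1(C)O`: > 50000 nM (a limit of the assay)
- compound 2 `CC1=CC[C@H]2[C@H](CC[C@]2(C)O)C(C)(C)[C@@H]1CC[C@H]1[C@]2(C)CC[C@H](OC(=O)c3cccc([N+](=O)[O-])c3)C(C)(C)O[C@H]2CC[C@@]1(C)O`: 36000 nM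
- compound 3 `CC1=CC[C@H]2[C@H](CC[C@]2(C)O)C(C)(C)[C@@H]1CC[C@H]1[C@]2(C)CC[C@H](OC(=O)c3ccccc3[N+](=O)[O-])C(C)(C)O[C@H]2CC[C@@]1(C)O`: 5200 nM

Among the measured compounds shown here, compound 3, at 5200 nM, has the lowest number so far. Compound 4 `CC1=CC[C@H]2[C@H](CC[C@]2(C)O)C(C)(C)[C@@H]1CC[C@H]1[C@]2(C)CC[C@H](OC(=O)c3ccc(C(F)(F)F)cc3F)C(C)(C)O[C@H]2CC[C@@]1(C)O` carries 2-fluoro-4-(trifluoromethyl)phenyl in place of 2-nitrophenyl on a carbonyl carbon. The measured steps that bear on this change alter the same group: a 6.9-fold lower number from compound 2 to compound 3 (0.84 log units; beyond the scatter) and an at least 9.6-fold lower number from compound 1 to compound 3 (0.98 log units; beyond the scatter). Both compound 1 and compound 2 sit higher than compound 3, so a modest rise in this assay is expected on leaving 2-nitrophenyl. The expected step is a 2.7-fold higher number from compound 3 to compound 4 (0.43 log units; beyond the scatter). For compound 4 the estimate is 14000 nM, with an expected range of 3500 nM to 50000 nM.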

Compound 4, half-maximal inhibitory concentration: > 50000 nM
Compound 4 was reported as a limit; the forecaster's own chance of this, stated with the estimate: 20%; middle value at least 3.5-fold (0.55 log units) from the limit.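

In this assay, 2-nitrophenyl is not simply replaceable on this carbonyl carbon: 2-fluoro-4-(trifluoromethyl)phenyl gives an at least 9.6-fold higher number from compound 3 to compound 4 (0.98 log units; beyond the scatter). Against 3-nitrophenyl the change gives an at least 1.3-fold higher number from compound 2 to compound 4 (0.14 log units; that floor lies within the scatter), so no order can be drawn for that pair, and the step involving compound 1 cannot be read. Compound 4 is reported only as a limit, which compound 1 shares: the limit of > 50000 nM in this assay, at which 2 of the 4 values shown sit.

The compounds shown leave open whether the lower number of compound 3 depends on the nitro group itself. An amine or a nitrile on the phenyl ring would test this.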